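Working notes: methoxy in place of phenyl

The source may report more compounds than this note shows. Statements on the series, on what has been measured and on what is new or still open speak of the compounds shown alone.

- compound 1 `N=C(N)N/N=C(/C=C/c1ccc(Cl)cc1)c1ccccc1`: 700 nM
- compound 2 `N=C(N)N/N=C(/C=C/c1ccc(-c2ccccc2)cc1)c1ccccc1`: 800 nM
- compound 3 `COc1ccc(/C=C/C(=N/NC(=N)N)c2ccccc2)cc1`: not yet measured

In a functional assay on MCF7 cells (Homo sapiens) for antiproliferative activity, read by MTT assay, with a stated time of 48 h (on this read-out lower numbers stand for stronger inhibition and higher numbers for weaker inhibition), compound 2 gives 800 nM, within the scatter of compound 1. The next change is methoxy in place of phenyl on an aromatic carbon. Going by the values given here, one measured step bears on it, phenyl in place of chloro on an aromatic carbon: a 1.1-fold higher number from compound 1 to compound 2 (0.06 log units; within the scatter). Among the compounds with values here, with only that small step to go on, no step beyond the scatter is expected in this assay, though no measured compound yet carries methoxy. The estimated step is a 1.1-fold lower number from compound 2 to compound 3 (0.03 log units; within the scatter). Compound 3 is expected at 750 nM, with an estimated range of 300 nM to 1800 nM.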

Compound 3, half-maximal inhibitory concentration: 14000 nM
The estimate for compound 3 lay 19-fold (1.27 log units) below the measured number; the whole stated range lies below it.
By their numbers in this assay, from the lowest: compounds 1 and 2 (each within the scatter of the next); then compound 3.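

In this assay this aromatic carbon, para to a large group, is not indifferent to its substituent: methoxy gives an 18-fold higher number from compound 2 to compound 3 (1.24 log units; beyond the scatter) and a 20-fold higher number from compound 1 to compound 3 (1.30 log units; beyond the scatter) in the same series. Chloro and phenyl had stayed within the scatter of each other, so the earlier pair gave no sign of such a large step. No available measurement accounts for the step.

From the compounds shown here alone, it remains open whether the step is particular to methoxy or is shared by hydroxyl, ethoxy or an amine on this carbon. A methyl group here would test whether the oxygen matters.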